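The source may hold more compounds than are shown below. What is called first, only, known or untested is meant among the compounds shown, and "the series" means these compounds.

Measured so far in a physicochemical assay for solubility, with a stated time of 24 h, tested at 30 mg/mL; a lower number here means a less soluble compound, a higher number a more soluble compound:
compound 1 `Cc1ccc(Nc2c(NCCCCCC(=O)NO)c(=O)c2=O)cc1`, 1800000 nM;
compound 2 `Cc1ccc(Nc2c(NC(C)CCCCC(=O)NO)c(=O)c2=O)cc1`, 4900000 nM;
compound 3 `CC(CCCCC(=O)NO)Nc1c(Nc2ccc(C(F)(F)F)cc2)c(=O)c1=O`, 20000000 nM.

Compound 4 `CC(C)(CCCCC(=O)NO)Nc1c(Nc2ccc(C(F)(F)F)cc2)c(=O)c1=O` has not yet been measured. The difference between the core of compound 1 and the core of compound 3 is not broken down here. Between compound 1 and compound 2 the change is methyl in place of hydrogen on a saturated chain carbon bound to a nitrogen on an aromatic ring and a saturated chain carbon, and it made the step of a 2.7-fold higher number from compound 1 to compound 2 (0.43 log units; beyond the scatter). Between compound 3 and compound 4 the change is methyl in place of hydrogen on a saturated chain carbon bound to a nitrogen on an aromatic ring and two saturated chain carbons. The two changes are the same kind of change, not the same: in compound 2 the entering methyl sits on a saturated chain carbon bound to a nitrogen on an aromatic ring and a saturated chain carbon, whereas in compound 4 that carbon is bound to a nitrogen on an aromatic ring and two saturated chain carbons. Compound 3 already stands highest of the three, with a 4.1-fold higher number from compound 2 to compound 3 (0.61 log units; beyond the scatter). From compound 3 to compound 4 a step of about a 2.3-fold higher number from compound 3 to compound 4 (0.35 log units; beyond the scatter) in this assay is expected, resting on the earlier step of a 2.7-fold higher number from compound 1 to compound 2 (0.43 log units; beyond the scatter). Compound 4 is therefore estimated at 45000000 nM, with a likely range from 15000000 nM to 90000000 nM.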

Compound 4, solubility: 30000000 nM
Beside the measured number, compound 4's estimate is 1.5-fold (0.18 log units) above it; the range from low to high includes it.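

In this assay the methyl in place of hydrogen on a saturated chain carbon bound to a nitrogen on an aromatic ring and two saturated chain carbons gives a 1.5-fold higher number from compound 3 to compound 4 (0.18 log units; within the scatter) and so cannot be told from no change, whereas the related methyl on the core of compound 1 gave a 2.7-fold higher number from compound 1 to compound 2 (0.43 log units; beyond the scatter) and stood beyond the scatter. This shows that a step of that kind did not reappear beyond the scatter in this one further pair, but it does not show that the core decides the outcome, since the two changes differ in their carbon as well as in their core and each rests on a single pair. No measurement given here accounts for the result.

From the compounds shown here alone, it remains open how a methyl on a carbon bound to two saturated chain carbons would read on the core of compound 1. Also open, going by these compounds, is how this assay would respond on either core to an ethyl in place of the entering methyl, or to a longer chain or an amine on the chain.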